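Two Measured Aryl Ethers and an Untested Dichloro Analogue

The source may hold more compounds than are shown below. What is called first, only, known or untested is meant among the compounds shown, and "the series" means these compounds.

Compound 1, `CN(C)C(=O)n1nnnc1-c1ccc(Oc2ccccc2)cc1`, gives 7 nM.
Compound 2, `Cc1ccc(Oc2ccc(-c3nnn(C(=O)N(C)C)n3)cc2)cc1`, gives 24 nM.

Both numbers come from an assay on microsomes from brain (strain Sprague-Dawley) for inhibition of Fatty-acid amide hydrolase 1 (Rattus norvegicus), read by HPLC, with stated times of 10 min and 45 min; a lower number here means a stronger inhibitor, a higher number a weaker inhibitor. Compound 2 stands at the higher of the two numbers, meaning it is the weaker inhibitor of the pair, and its gap to compound 1 lies beyond the usual scatter of repeated measurements, so the two compounds can be told apart with some confidence.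

Compound 3, `CN(C)C(=O)n1nnc(-c2ccc(Oc3ccc(Cl)c(Cl)c3)cc2)n1`, has not yet been measured in this assay. It differs from compound 2 in one place: 3,4-dichlorophenyl in place of 4-methylphenyl on an oxygen on an aromatic ring. For the measured compounds named here, no step between two measured compounds involves this kind of exchange, so there is nothing in the data to anchor its size or direction. With only the two measured points to lean on, the step from compound 2 to compound 3 is expected to be small and is estimated as a 1.0-fold higher number from compound 2 to compound 3 (0.02 log units; within the scatter), which is not beyond the scatter. Compound 3 is therefore expected to land near 25 nM, with a range from 8 nM to 80 nM.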

Compound 3, half-maximal inhibitory concentration: 11 nM
Compound 3: the middle estimate sits 2.3-fold (0.36 log units) above what was measured, and the stated range covers the measured number.
By their numbers in this assay, from the lowest: compounds 1 and 3 (each within the scatter of the next); then compound 2.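

In this assay, for the compounds shown here, putting 3,4-dichlorophenyl in place of 4-methylphenyl on the oxygen gives a 2.2-fold lower number from compound 2 to compound 3 (0.34 log units; beyond the scatter), the only change in this set that can be read on its own. The step is modest but beyond the scatter, so this position accepts two chlorine atoms in place of a methyl group, and inhibition is not lost but somewhat stronger with the new group. Nothing measured alongside these numbers says what lies behind the step.

The compounds shown leave open whether both chlorine atoms are needed for this gain, as a ring with a single chlorine, such as 4-chlorophenyl, is not among them, and how this position would respond to quite different groups on that ring, such as a methoxy group, an amine or a carboxylic acid. As far as these compounds go, it also remains open whether the same exchange would have a similar effect on the core of compound 1, whose structure differs from the core shared by compound 2 and compound 3.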